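The source may report more compounds than this note shows. Statements on the series, on what has been measured and on what is new or still open speak of the compounds shown alone.

In a functional assay on a cell-free system (plasma, Homo sapiens), with a stated time of 3 min (a higher number here means a weaker inhibitor, a lower number a stronger inhibitor), compound 1 `O=C(NCc1cc(Cl)ccc1-n1cnnn1)[C@@H]1[C@H]2C[C@H]2CN1C(=O)[C@H](O)CC1CC1` gives 1400 nM. That is the second highest of the three numbers measured: compound 2 `CCCC[C@@H](O)C(=O)N1N=CC[C@H]1C(=O)NCc1cc(Cl)ccc1-n1cnnn1` gives 610 nM, a lower number beyond the scatter, while compound 3 `COC(C)(C)[C@@H](O)C(=O)N1N=CC[C@H]1C(=O)NCc1cc(Cl)ccc1-n1cnnn1` gives 3700 nM, a higher number beyond the scatter. Compound 4 `O=C(NCc1cc(Cl)ccc1-n1cnnn1)[C@@H]1[C@H]2C[C@H]2CN1C(=O)[C@H](O)C1CCCCC1` differs from compound 1 in a single place: cyclohexyl in place of cyclopropylmethyl on a saturated chain carbon bound to a carbonyl carbon and an oxygen on a saturated carbon. For the measured compounds named here, the only measured step at that same place is a 6.1-fold higher number from compound 2 to compound 3 (0.78 log units; beyond the scatter), made on a different core, where 1-methoxy-1-methylethyl took the place of butyl. Going by the values given here, the change from compound 1 to compound 4 instead swaps a three-membered ring of carbon only for a six-membered ring of carbon only, and no measured step tracks such a swap, so the expected step of a 1.2-fold lower number from compound 1 to compound 4 (0.07 log units; within the scatter) is small, likely within the scatter, with its direction uncertain. Compound 4 is therefore estimated at 1200 nM in this assay, with a range from 350 nM to 4500 nM.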

Compound 4, half-maximal inhibitory concentration: 850 nM
Compound 4: the middle estimate sits 1.4-fold (0.15 log units) above what was measured, and the stated range covers the measured number.
By their numbers in this assay, from the lowest: compounds 2, 4 and 1 (each within the scatter of the next, the first and the last beyond it); then compound 3.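

In this assay, a 1.6-fold lower number from compound 1 to compound 4 (0.22 log units; within the scatter), so on the core of compound 1 this swap of one carbon-only ring group for another leaves the two compounds unranked. For the compounds shown here, the earlier step at this place, a 6.1-fold higher number from compound 2 to compound 3 (0.78 log units; beyond the scatter), lay beyond the scatter but was made on a different core and brought in 1-methoxy-1-methylethyl; the new pair adds a first reading on this core, where a larger group of carbon only gives no change that can be told from the scatter. No measurement here offers an explanation for this result.

From the compounds shown here alone, it remains open whether a group of another kind at this place, such as an amine or a carboxylic acid, would shift the number beyond the scatter on this core. Going by these compounds, it is also open whether 1-methoxy-1-methylethyl would give a step of similar size here.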